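The compounds below may be only part of what the source reports. "The series", "measured", "known", "first", "only" and "open" are said of these compounds alone.

Within the data shown here, compound 2 `COc1cccc(NC(=O)Oc2cc(=O)n(CCCO)c3c2CC(C/C=C(\C)CCC=C(C)C)C(C)(C)C3)c1` stands at the top of the two numbers so far in a functional assay on PANC-1 cells (Homo sapiens) for inhibition, read by MTT assay, with a stated time of 24 h, tested at 10 uM; a higher number here means more inhibition at the concentration tested (going by the name of the read-out), a lower number less inhibition: compound 2 reaches 47%, whereas compound 1 `CC(C)=CCC/C(C)=C/CC1Cc2c(OCC=C(C)C)cc(=O)n(CCCO)c2CC1(C)C` gives 30.3%. Among the measured compounds shown here, that gap is the only measured step, a number 16.7 percentage points higher from compound 1 to compound 2 (beyond the scatter), and it concerns the group on an oxygen on an aromatic ring, not the group on the amide-type nitrogen. Compound 3 `CC(C)=CCC/C(C)=C/CC1Cc2c(OC(=O)Nc3ccc(Cl)c(Cl)c3)cc(=O)n(CCCO)c2CC1(C)C` keeps the (3-methoxyphenyl)carbamoyl oxygen linkage of compound 2 intact apart from the ring at its end: 3,4-dichlorophenyl in place of 3-methoxyphenyl on an amide-type nitrogen. For the measured compounds named here, no measured pair varies the group on the amide-type nitrogen, so the step from compound 1 to compound 2 does not bear directly on this change, and the data give no direction for it. The expected step is therefore a number 3 percentage points higher from compound 2 to compound 3 (within the scatter) in this assay, which is not expected to go beyond the scatter. The estimate for compound 3 in this assay is 50%, in a range from 30% to 70%.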

Compound 3, a percentage reported as inhibition, at one concentration (the size of the read-out at that concentration, not a potency): 20%
Compound 3: middle estimate off by 30 percentage points, on the high side; measured number below the stated range.
By their numbers in this assay, from the lowest: compound 3; then compound 1; then compound 2.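

Changing the ring at the end of the carbamoyl group is not neutral: in this assay, 3,4-dichlorophenyl in place of 3-methoxyphenyl on the amide-type nitrogen gives a number 27 percentage points lower from compound 2 to compound 3 (beyond the scatter) and so moves the number beyond the scatter. The carbamoyl linkage on the oxygen therefore does not bring a rise by itself, since (3,4-dichlorophenyl)carbamoyl in place of 3-methylbut-2-en-1-yl gives a number 10.3 percentage points lower from compound 1 to compound 3 (beyond the scatter) while the (3-methoxyphenyl)carbamoyl group gives a number 16.7 percentage points higher from compound 1 to compound 2 (beyond the scatter) in the opposite direction, and the sign of that replacement depends, across these three compounds, on the ring carried by the nitrogen. No measurement at hand accounts for the difference between the two rings.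

What the compounds shown leave open is which part of the change matters, the loss of the methoxy group or the arrival of the two chlorines, as a plain phenyl, a 3-chlorophenyl or a 4-chlorophenyl on this nitrogen would help to separate. From the compounds shown here alone, it also remains open whether an aromatic ring is needed here at all, or whether a cyclohexyl group or a short alkyl chain on the same nitrogen would read the same way.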